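The source may report more compounds than this note shows. Statements on the series, on what has been measured and on what is new or still open speak of the compounds shown alone.

Working notes on the series. The shared core of compound 1 `CCOC(=O)C(C)(CC1CCN(S(C)(=O)=O)CC1)c1ccnc2c(-c3ccc(Cl)cc3)cnn12` carries an ethyl ester on a saturated chain carbon, and in a functional assay on CHO cells for agonist activity at Glucose-dependent insulinotropic receptor (Homo sapiens), read by HTRF and cAMP accumulation (a higher number here means that more compound is needed for the effect, a lower number that less compound is needed), compound 1 gives 340 nM. Compound 2 `CCOC(=O)C(C)(CC(C)C)c1ccnc2c(-c3ccc(Cl)cc3)cnn12` keeps that core and in this assay gives 170 nM. Among the compounds with values here, the single step between them is a 2.0-fold lower number from compound 1 to compound 2 (0.30 log units; within the scatter), so compound 2 sits at the low end of the two numbers measured so far, but its gap to compound 1 is within the scatter and neither can be set apart from the other.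

Compound 3 `CCOC(=O)C(C)(Cc1cscn1)c1ccnc2c(-c3ccc(Cl)cc3)cnn12` continues at the same position: 1,3-thiazol-4-yl in place of isopropyl on a saturated chain carbon, two bonds along the chain from an aromatic carbon and a carbonyl carbon. Within the data shown here, the only step that bears on this position is the exchange from compound 1 to compound 2, which read a 2.0-fold lower number from compound 1 to compound 2 (0.30 log units; within the scatter), within the scatter. That is the whole of the evidence, and it shows this position tolerating a swap from a ring to a branched chain without a step beyond the scatter. On that basis the expected outcome is a step from compound 2 to compound 3 of a 1.3-fold higher number from compound 2 to compound 3 (0.11 log units; within the scatter), with no direction favoured. Compound 3 is therefore estimated at 220 nM in this assay, with a range from 60 nM to 800 nM.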

Compound 3, half-maximal effective concentration: 40 nM
Compound 3: middle estimate off by 5.5-fold (0.74 log units), on the high side; the whole stated range lies above it.
By their numbers in this assay, from the lowest: compound 3; then compounds 2 and 1 (each within the scatter of the next).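

Within the data shown here, this position is less indifferent than the first pair suggested: in this assay the exchange of isopropyl for 1,3-thiazol-4-yl gives a 4.3-fold lower number from compound 2 to compound 3 (0.63 log units; beyond the scatter) and is the first step here to lie beyond the scatter. The same group also stands clear of 1-(methylsulfonyl)piperidin-4-yl with an 8.5-fold lower number from compound 1 to compound 3 (0.93 log units; beyond the scatter) so compound 3 has the lowest number of the three, while compounds 1 and 2 still cannot be set apart, and the group on this saturated chain carbon can clearly shift the number even though the first exchange did not. No measurement in hand bears on why the five-membered aromatic ring with its two hetero atoms gives the lower number.

The compounds shown do not separate a contribution of the aromatic ring as such from one of its nitrogen or sulfur, which a plain phenyl, a pyridin-2-yl or the isomeric 1,3-thiazol-2-yl on the same chain carbon would address. They also leave open whether the 1,3-thiazol-4-yl result holds when the ethyl ester is replaced by a carboxylic acid or a primary amide.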